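Bulky Dialkylphenyl Urea Expected to Regain Inhibitory Potency

The source may hold more compounds than are shown below. What is called first, only, known or untested is meant among the compounds shown, and "the series" means these compounds.

Measured compounds:
Compound 1 `CCCCCCCC/C=C\CCCCCCCCNC(=O)Nc1c(C)cccc1C`: 160 nM
Compound 2 `CCCCCCCC/C=C\CCCCCCCCNC(=O)Nc1c(C)cc(C)cc1C`: 2900 nM
Compound 3 `CCCCCCCC/C=C\CCCCCCCCNC(=O)Nc1ccc(F)cc1F`: 4700 nM

All three were tested in an assay on microsomes from intestinal mucosa for inhibition of acyl-CoA:cholesterol acyltransferase (Oryctolagus cuniculus); a higher number here means a weaker inhibitor, a lower number a stronger inhibitor. Compound 3 gives the highest number of the three; its nearest neighbour is compound 2, and the step of a 1.6-fold higher number from compound 2 to compound 3 (0.21 log units; within the scatter) lies within the scatter, so the two cannot be ranked against each other. Compound 1 stands far apart, as the step of a 29-fold higher number from compound 1 to compound 3 (1.47 log units; beyond the scatter) shows.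

The unmeasured compound 4 `CCCCCCCC/C=C\CCCCCCCCNC(=O)Nc1c(CC)cccc1C(C)C` differs from compound 3 in one place: 2-ethyl-6-isopropylphenyl in place of 2,4-difluorophenyl on an amide-type nitrogen. Going by the values given here, two measured steps bear on this. The step of a 29-fold higher number from compound 1 to compound 3 (1.47 log units; beyond the scatter) shows that exchanging the 2,6-dimethylphenyl for the 2,4-difluorophenyl weakens inhibition strongly, and compound 4 carries a 2,6-dialkyl pattern of the same kind as compound 1. The step of an 18-fold higher number from compound 1 to compound 2 (1.26 log units; beyond the scatter) shows that a methyl added on an aromatic carbon also weakens inhibition strongly; compound 4 carries no such extra group. Both steps therefore point in the same direction, and a large decrease in this assay is expected, roughly undoing the step from compound 1 to compound 3. The expected step is a 24-fold lower number from compound 3 to compound 4 (1.37 log units; beyond the scatter). Compound 4 is accordingly estimated at 200 nM, with a range from 60 nM to 700 nM.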

Compound 4, half-maximal inhibitory concentration: 37 nM
Compound 4: the middle estimate sits 5.4-fold (0.73 log units) above what was measured; the whole stated range lies above it.
By their numbers in this assay, from the lowest: compound 4; then compound 1; then compounds 2 and 3 (each within the scatter of the next).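

In this assay, the 2-ethyl-6-isopropylphenyl on the amide-type nitrogen goes beyond the 2,6-dimethylphenyl, with a modest gain that lies beyond the scatter (a 4.3-fold lower number from compound 1 to compound 4 (0.64 log units; beyond the scatter)). The earlier compounds shown here showed only losses from the 2,6-dimethylphenyl, whereas this exchange gives a large gain over the 2,4-difluorophenyl (a 130-fold lower number from compound 3 to compound 4 (2.10 log units; beyond the scatter)) and over the 2,4,6-trimethylphenyl (a 78-fold lower number from compound 2 to compound 4 (1.89 log units; beyond the scatter)). More carbon in the aryl group therefore does not by itself raise the number at this place: compound 4 carries more carbon than compound 1 and gives a lower number, while compound 2 also carries more carbon than compound 1 and goes against any simple trend by giving a higher one.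

The compounds shown leave open whether a 2,6-diisopropylphenyl or a 2,6-diethylphenyl on the same nitrogen would lower the number further, and whether the 2-ethyl-6-isopropylphenyl would keep its standing with a shorter chain in place of the long unsaturated one. Nothing given here accounts for why the 2-ethyl-6-isopropylphenyl gives the lowest number of the four.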